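Replacing the 4-hydroxyphenyl group of compound 1

The compounds below may be only part of what the source reports. "The series", "measured", "known", "first", "only" and "open" are said of these compounds alone.

compound 1 `O=C(Cc1csc2nc(-c3ccc(Br)cc3)cn12)N/N=C/c1ccc(O)cc1`: < 100000 nM
compound 2 `COc1cccc(OC)c1/C=N/NC(=O)Cc1csc2nc(-c3ccc(Br)cc3)cn12`: 24000 nM

In a functional assay on SNB-75 cells (Homo sapiens) for inhibition, read by sulforhodamine B assay, with a stated time of 48 h (a higher number here means a weaker inhibitor of growth, a lower number a stronger inhibitor of growth), compound 1 gives < 100000 nM. That value is a limit of the assay and not a number.

Compound 3 `O=C(Cc1csc2nc(-c3ccc(Br)cc3)cn12)N/N=C/c1ccc(Cl)cc1Cl` keeps the core of compound 1 and differs in one group: 2,4-dichlorophenyl in place of 4-hydroxyphenyl on a carbon with a double bond to nitrogen. In words, 2,4-dichlorophenyl stands in place of 4-hydroxyphenyl on a carbon with a double bond to nitrogen.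

Among the measured compounds shown here, only one measured step changes the group at this place. It is a step that the limit leaves unreadable from compound 1 to compound 2, and it gives neither a size nor a direction for the change to compound 3. For the measured compounds named here, the only exact number in this assay therefore comes from compound 2 at 24000 nM, and the expectation for compound 3 is anchored there, with a wide margin. No firm direction can be expected from the limit alone.

The estimated step is a step that the limit leaves unreadable from compound 1 to compound 3. In this assay the expected value for compound 3 is 20000 nM, with an estimated range from 6000 nM to 60000 nM.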

Compound 3, concentration for 50% growth inhibition: 37200 nM
Estimate against measurement, compound 3: 1.9-fold (0.27 log units) below; the range from low to high includes it.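

Compound 3 gives a second exact number at this place, on a carbon with a double bond to nitrogen, and with it the first readable step there: in this assay the change gives a 1.6-fold higher number from compound 2 to compound 3 (0.19 log units; within the scatter). The 2,4-dichlorophenyl group of compound 3 and the 2,6-dimethoxyphenyl group of compound 2 carry different substituents, chlorine in one and methoxy in the other, yet their values stand within the scatter of each other, so this exchange leaves growth inhibition unchanged as far as this assay can tell. The steps from compound 1 to the other two compounds cannot be read, because the value of compound 1 is a limit of the assay and not a number: the limit of < 100000 nM in this assay, at which 1 of the 3 values shown sits.

Going by these compounds, it therefore stays open whether the 4-hydroxyphenyl group of compound 1, with its hydrogen-bond donor and acceptor, differs at all from the two groups that carry neither hydroxyl nor any other donor. Also open, on these data alone, is whether an amine or a carboxylic acid on the phenyl ring at this place would take the value beyond the scatter around compound 2 and compound 3.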